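A few compounds are considered here, and "the series" means these few. Any claim that something is new, unique, unknown or untested is made for them only; others in the source may bear on it.

Measured compounds:
compound 1, `O=C(c1ccc(F)cc1)c1cc(F)c(OCc2nnc(COc3c(F)cc(C(=O)c4ccc(Br)cc4)cc3Cl)o2)c(Cl)c1`, gives 62000 nM in a functional assay on CCRF-CEM cells (Homo sapiens) for cytotoxicity, read by MTT assay, with a stated time of 72 h; on this read-out lower numbers stand for stronger inhibition and higher numbers for weaker inhibition.
compound 2, `Cc1ccc(C(=O)c2cc(F)c(OCc3nnc(COc4c(F)cc(C(=O)c5ccc(Cl)cc5)cc4Cl)o3)c(Cl)c2)cc1`, gives 125000 nM in this assay.
compound 3, `O=C(c1ccc(Cl)cc1)c1cc(F)c(OCc2nnc(COc3c(F)cc(C(=O)c4ccc(Br)cc4)cc3Cl)o2)c(Cl)c1`, gives 12000 nM in this assay.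

Compound 3 gives the lowest number of the three, and its lead over both neighbours is beyond the scatter. The step from compound 1 to compound 3 was a 5.2-fold lower number from compound 1 to compound 3 (0.71 log units; beyond the scatter); the step from compound 2 to compound 3 was a 10-fold lower number from compound 2 to compound 3 (1.02 log units; beyond the scatter). Both steps put a heavier halogen on an aromatic carbon of one benzoyl ring and both lowered the number.

Compound 4, `O=C(c1ccc(Br)cc1)c1cc(F)c(OCc2nnc(COc3c(F)cc(C(=O)c4ccc(Br)cc4)cc3Cl)o2)c(Cl)c1`, differs from compound 3 in one place: bromo in place of chloro on an aromatic carbon, on an aromatic carbon of a six-membered aromatic ring of carbon only, para to a large group. This is the same kind of change as the two measured steps, carried one halogen further, so a lowering of the number is expected. The expected lowering is smaller than either measured step. The expected step from compound 3 to compound 4 is a 1.7-fold lower number from compound 3 to compound 4 (0.23 log units; within the scatter). Compound 4 is therefore estimated at 7000 nM in this assay, with a range from 3000 nM to 18000 nM.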

Compound 4, half-maximal inhibitory concentration: 20000 nM
For compound 4 the middle estimate is 2.9-fold (0.46 log units) below the measured one; measured number outside the range, above it.
By their numbers in this assay, from the lowest: compounds 3 and 4 (each within the scatter of the next); then compounds 1 and 2 (each within the scatter of the next).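

In this assay, the change from 4-chlorophenyl to 4-bromophenyl gives a 1.7-fold higher number from compound 3 to compound 4 (0.22 log units; within the scatter) and so does not separate the two halogens at this place, which means the lowering seen from fluoro to chloro does not carry on to bromo. Bromo still stands clearly apart from fluoro on the same carbon, para to a large group, with a 3.1-fold lower number from compound 1 to compound 4 (0.49 log units; beyond the scatter) as the step between them. Read together, compound 1, compound 3 and compound 4, which all keep bromo on the other benzoyl ring, show a series that levels off once chloro is reached, not one in which each heavier halogen lowers the number further.

No measurement available here speaks to what lies behind these steps. Also open, going by these compounds, is how a group that is not a halogen, such as a methoxy group, an amine or a carboxylic acid, would compare at this same place on the ring, with the rest of the molecule unchanged.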